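Predicting Compound 4 from a Difluoro to Dichloro Swap

A few compounds are considered here, and "the series" means these few. Any claim that something is new, unique, unknown or untested is made for them only; others in the source may bear on it.

Three close relatives of one shared core have been measured in a functional assay on BCG823 cells (Homo sapiens) for inhibition, read by MTT assay, with a stated time of 72 h; on this read-out lower numbers stand for stronger inhibition and higher numbers for weaker inhibition. Compound 1 `CN(C(=O)NC(=O)c1ccccc1F)c1nc(C(F)(F)F)c(C(=O)N/N=C/c2ccccc2C(F)(F)F)s1` gives 4.67 ug/mL, compound 2 `Cc1nc(N(C)C(=O)NC(=O)c2c(F)cccc2F)sc1C(=O)N/N=C/c1ccccc1C(F)(F)F` gives 7.88 ug/mL, and compound 3 `CN(C(=O)NC(=O)c1c(F)cccc1F)c1nc(C(F)(F)F)c(C(=O)N/N=C/c2ccccc2C(F)(F)F)s1` gives 17 ug/mL. Compound 3 therefore stands at the highest number of the three, which on this read-out means the weakest inhibition. Both measured steps end at compound 3: a 2.2-fold higher number from compound 2 to compound 3 (0.33 log units; beyond the scatter), where the change is trifluoromethyl in place of methyl on an aromatic carbon, and a 3.6-fold higher number from compound 1 to compound 3 (0.56 log units; beyond the scatter), where the change is fluoro in place of hydrogen on an aromatic carbon. Each step is modest, and each sits beyond the scatter.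

Compound 4 `CN(C(=O)NC(=O)c1c(Cl)cccc1Cl)c1nc(C(F)(F)F)c(C(=O)N/N=C/c2ccccc2C(F)(F)F)s1` has not yet been measured. It differs from compound 3 in one place only: 2,6-dichlorophenyl in place of 2,6-difluorophenyl on a carbonyl carbon. Neither measured step touches this part of the molecule, and neither involves 2,6-dichlorophenyl in place of 2,6-difluorophenyl on a carbonyl carbon, so no direct guide exists. The expectation is a small step, a 1.2-fold lower number from compound 3 to compound 4 (0.08 log units; within the scatter), quite possibly within the scatter, with wide uncertainty in both directions. Compound 4 is estimated at 14 ug/mL, with a range from 5 ug/mL to 40 ug/mL.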

Compound 4, half-maximal inhibitory concentration: 4.12 ug/mL
Estimate against measurement, compound 4: 3.4-fold (0.53 log units) above; the whole stated range lies above it.
By their numbers in this assay, from the lowest: compounds 4, 1 and 2 (each within the scatter of the next); then compound 3.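

At this place on a carbonyl carbon, the kind of halogen matters as well as the number of halogens: in this assay, 2,6-dichlorophenyl in place of 2,6-difluorophenyl gives a 4.1-fold lower number from compound 3 to compound 4 (0.62 log units; beyond the scatter) for a swap that keeps the count of heavy atoms unchanged. The earlier compounds shown here showed this ring only through a second fluoro, which gave a 3.6-fold higher number from compound 1 to compound 3 (0.56 log units; beyond the scatter) and could have suggested that any ring carrying two halogens here ends up with a higher number, but 2,6-dichlorophenyl in place of 2-fluorophenyl gives a 1.1-fold lower number from compound 1 to compound 4 (0.05 log units; within the scatter) and so shows that this does not hold for chlorine. Nothing available explains why chlorine and fluorine part ways at this position.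

The compounds shown leave open whether the low number of compound 4 is special to chlorine or would also appear with other groups on this ring, such as bromine or methoxy. They also leave open whether the same swap would give a similar step on the methyl-bearing core of compound 2, where only the 2,6-difluorophenyl group appears.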